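Methyl for methoxy on the shared core: clearance notes

The source may report more compounds than this note shows. Statements on the series, on what has been measured and on what is new or still open speak of the compounds shown alone.

Measured compounds:
compound 1, `COc1ccc2oc(SCCC(=O)N3CCCC3)nc2c1`, 6.1 mL/min/g
compound 2, `CC1CCN(C(=O)CCSc2nc3cc(Cl)ccc3o2)C1`, 10.1 mL/min/g

In an ADME assay on microsomes from liver (Homo sapiens) for metabolic stability, read by LC-MS, using NADPH, with a stated time of 45 min, tested at 0.5 uM (on this read-out higher numbers stand for fast clearance and lower numbers for slow clearance), compound 1 gives 6.1 mL/min/g, and compound 2 gives 10.1 mL/min/g. Compound 1 holds the lower of the two numbers, but its gap to compound 2 lies within the scatter, so the two compounds cannot be ordered against each other in this assay. Among the compounds with values here, no pair of measured compounds differs in a single place, so the size of any one structural change in this assay is not yet known from measurement.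

The next compound to go into this assay is compound 3, `Cc1ccc2oc(SCCC(=O)N3CCCC3)nc2c1`. Relative to compound 1 the change is methyl in place of methoxy on an aromatic carbon. Within the data shown here, no measured pair shows what this exchange does in this assay; the only anchor is compound 1 with its 6.1 mL/min/g.

The step from compound 1 to compound 3 is expected to be a 1.1-fold higher number from compound 1 to compound 3 (0.06 log units; within the scatter), with no direction that reaches beyond the scatter. Compound 3 is estimated at 7 mL/min/g, within a range from 3.5 mL/min/g to 14 mL/min/g.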

Compound 3, intrinsic clearance in a liver preparation (reported as CLH), per the amount of preparation that the assay uses: 9.3 mL/min/g
Compound 3: the middle estimate sits 1.3-fold (0.12 log units) below what was measured; measured number inside the range.
By their numbers in this assay, from the lowest: compounds 1, 3 and 2 (each within the scatter of the next).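

Within the data shown here, this is the first single-place exchange with a measured step in this assay, and methyl in place of methoxy on an aromatic carbon of the shared core gives a 1.5-fold higher number from compound 1 to compound 3 (0.18 log units; within the scatter) on this read-out. At this position, then, the exchange removes an oxygen and a hydrogen-bond acceptor without a shift in clearance that can be told from repeat scatter, and this single pair sets no direction for the change. Nothing at hand accounts for the step or links it to a property of either group.

Still open, on these data alone, is whether this aromatic carbon tolerates groups of a different kind as readily, such as fluorine, a nitrile, an amine or a carboxylic acid, since methoxy and methyl are the only two compared here on an otherwise unchanged structure. Also open, as far as these compounds go, is whether the same exchange gives a similar step when the pyrrolidine amide is replaced by another amide or the chain carrying it is made longer, as one pair cannot show how far the reading carries across the series.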